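Benzyl Ester in Place of tert-Butyl Ester: Cytotoxicity Outlook

The compounds below may be only part of what the source reports. "The series", "measured", "known", "first", "only" and "open" are said of these compounds alone.

Compound 1: `CCOC(=O)C1=C(C)N/C(=C/c2cc(C)n(Cc3ccc(C(F)(F)F)cc3)c2C)C1=O` — 72000 nM
Compound 2: `CC1=C(C(=O)OC(C)(C)C)C(=O)/C(=C\c2cc(C)n(-c3ccccc3C(F)(F)F)c2C)N1` — 110000 nM

In an ADME assay on L6 cells (Rattus norvegicus) for cytotoxicity, read by resazurin assay, with a stated time of 72 h (a lower number here means that less compound is needed, a higher number that more compound is needed for the effect), compound 1 gives 72000 nM and compound 2 gives 110000 nM. Compound 2 holds the higher of the two numbers, but its gap to compound 1 lies within the scatter, so the two cannot be told apart. Compound 3 `CC1=C(C(=O)OCc2ccccc2)C(=O)/C(=C\c2cc(C)n(-c3ccccc3C(F)(F)F)c2C)N1` differs from compound 2 by benzyl in place of tert-butyl on an oxygen next to a carbonyl group. Going by the values given here, no measured pair shows this change, so its size is unknown. The expected step is a 1.1-fold lower number from compound 2 to compound 3 (0.04 log units; within the scatter), not beyond the scatter. Compound 3 is estimated at 100000 nM, between 40000 nM and 250000 nM.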

Compound 3, half-maximal effective concentration in the L6 assay: 57000 nM
Compound 3: middle estimate off by 1.8-fold (0.24 log units), on the high side, within the range that was stated.
By their numbers in the L6 assay, from the lowest: compounds 3, 1 and 2 (each within the scatter of the next).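

In the L6 assay compound 2 gives 110000 nM and compound 3 gives 57000 nM here. Going by these compounds alone, in the L6 assay, benzyl in place of tert-butyl on an oxygen next to a carbonyl group gives a 1.9-fold lower number from compound 2 to compound 3 (0.29 log units; within the scatter), the first direct reading of this change at this position. In a physicochemical assay for solubility, read by nephelometry, measured as kinetic solubility, at pH 2.0 (a higher number here means a more soluble compound, a lower number a less soluble compound), compound 2 gives 3.1 ug/mL and compound 3 gives 1.6 ug/mL here. In the physicochemical assay, the same change gives a 1.9-fold lower number from compound 2 to compound 3 (0.29 log units; within the scatter), so neither read-out separates the two compounds, even though a six-membered aromatic ring enters. No measurement at hand speaks to why these results came out this way.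

Still open, going by these compounds, is whether a chain carrying an amine on this oxygen, or a carboxylic acid in place of the ester, would move either number beyond the scatter.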